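Bromo in place of methyl: estimate for compound 3

A few compounds are considered here, and "the series" means these few. Any claim that something is new, unique, unknown or untested is made for them only; others in the source may bear on it.

compound 1 `Cc1ccc(/C=C/C(=O)Oc2ccc(/C=C3\CCCCC3=O)cc2)cc1` gives 230000 nM
compound 2 `Cc1ccc(/C=C/C(=O)Oc2ccc(/C=C3\CCCC(CN(C)C)C3=O)cc2)cc1` gives 7020 nM

Going by the values given here, in a functional assay on CCRF-CEM cells (Homo sapiens) (on this read-out higher numbers stand for weaker inhibition and lower numbers for stronger inhibition), compound 2 holds the lower of the two numbers so far. Compound 3 `CN(C)CC1CCC/C(=C\c2ccc(OC(=O)/C=C/c3ccc(Br)cc3)cc2)C1=O` differs from it by bromo in place of methyl on an aromatic carbon as bromo in place of methyl on an aromatic carbon, para to a large group. Among the compounds with values here, the only measured step of a 33-fold lower number from compound 1 to compound 2 (1.52 log units; beyond the scatter) is large but lies at a saturated ring carbon and does not bear directly on this aromatic change. No step beyond the scatter is therefore expected, and the expected change is a 1.1-fold lower number from compound 2 to compound 3 (0.03 log units; within the scatter) in size. Compound 3 is estimated in this assay at 6500 nM with an expected range from 2500 nM to 17000 nM for repeat measurements.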

Compound 3, half-maximal inhibitory concentration: 4440 nM
The estimate for compound 3 lay 1.5-fold (0.17 log units) above the measured number, and the stated range covers the measured number.
By their numbers in this assay, from the lowest: compounds 3 and 2 (each within the scatter of the next); then compound 1.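

In this assay, bromo in place of methyl on an aromatic carbon, para to a large group, gives a 1.6-fold lower number from compound 2 to compound 3 (0.20 log units; within the scatter), which lies within the scatter. This aromatic position therefore accepts either group without a step beyond the scatter, whereas the change at the saturated ring carbon gave a 33-fold lower number from compound 1 to compound 2 (1.52 log units; beyond the scatter). Nothing measured here gives a reason for this result.

Still open, going by these compounds, is how an amine or a carboxylic acid at this position would read. Also open, on these data alone, is whether bromo gives a similar step on the core of compound 1, without the (dimethylamino)methyl group.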